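A few compounds are considered here, and "the series" means these few. Any claim that something is new, unique, unknown or untested is made for them only; others in the source may bear on it.

Measured in this series:
compound 1 `CCCOC(=O)C1=C(C)NC(=O)NC1c1cccs1` — 43%
compound 2 `CCCC(=O)C1=C(C)NC(=O)NC1c1cccs1` — 2%
compound 3 `CC1=C(C(=O)NC(C)C)C(c2cccs2)NC(=O)N1` — 2%

In an assay on membranes from CHO cells for displacement of a labelled ligand from adenosine receptor A1 (Homo sapiens), read by scintillation counting, with a stated time of 60 min, tested at 1 uM (a higher number here means more inhibition at the concentration tested (going by the name of the read-out), a lower number less inhibition), compound 1 gives 43%. Compound 2 gives 2% and compound 3 gives 2%. Compound 3 stands level with compound 2, the two together at the bottom of the three numbers, with no change at the digits printed from compound 2 to compound 3 (within the scatter). Compound 1 sits well apart from both, with a number 41 percentage points lower from compound 1 to compound 3 (beyond the scatter) and a number 41 percentage points lower from compound 1 to compound 2 (beyond the scatter); the only large movements seen so far come from exchanging the group on the carbonyl carbon.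

Compound 4 `CC1=C(c2ncc(C)o2)C(c2cccs2)NC(=O)N1` has not yet been measured in this assay. Against compound 3 the change is 5-methyl-1,3-oxazol-2-yl in place of isopropylcarbamoyl on a double-bonded ring carbon. None of the three measured steps covers this change: all of them kept the carbonyl and varied what sits on it, whereas here the whole isopropylcarbamoyl group leaves and an aromatic five-membered ring enters in its place. The measured steps show only that this position of the shared core can move the number strongly, and from the level of compound 3 the large steps point upward. A step of uncertain direction, likely within or modestly beyond the scatter, is therefore expected for a number 10 percentage points higher from compound 3 to compound 4 (within the scatter). For compound 4 the estimate is 12%, from 0% to 40%.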

Compound 4, a percentage reported as inhibition, at one concentration (the size of the read-out at that concentration, not a potency): 21%
Compound 4: the middle estimate sits 9 percentage points below what was measured; low and high end bracket the measured number.
By their numbers in this assay, from the lowest: compounds 2 and 3 (each within the scatter of the next); then compound 4; then compound 1.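

In this assay, the carbonyl at this position can be given up entirely: 5-methyl-1,3-oxazol-2-yl in place of isopropylcarbamoyl gives a number 19 percentage points higher from compound 3 to compound 4 (beyond the scatter), and in place of propylcarbonyl it gives a number 19 percentage points higher from compound 2 to compound 4 (beyond the scatter), so of the groups on this double-bonded ring carbon, the propoxycarbonyl of compound 1 is no longer the only one to stand clear of the bottom level. The same ring does not restore the whole of that level, with a number 22 percentage points lower from compound 1 to compound 4 (beyond the scatter), so the position now shows an intermediate level, not only a high one and a low one. Isopropylcarbamoyl and 5-methyl-1,3-oxazol-2-yl carry the same number of heavy atoms, so that count alone does not fix the number, and nothing available explains why the ring differs from either carbonyl group.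

Open, from the compounds shown here alone, is what the methyl on the ring contributes, which a plain 1,3-oxazol-2-yl or a 1,3-thiazol-2-yl group would help to settle. Equally open, going by these compounds, is how a carboxylic acid or the longer butoxycarbonyl chain would read at this position, and whether the steps seen here would hold with phenyl in place of thiophen-2-yl.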